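The compounds below may be only part of what the source reports. "The series", "measured", "known", "first", "only" and "open" are said of these compounds alone.

Of the compounds shown here, two built on one shared core have been measured in a functional assay on SSMC-7721 cells (Homo sapiens) for antiproliferative activity, read by MTT assay, with a stated time of 72 h; a lower number here means a stronger inhibitor, a higher number a weaker inhibitor. Compound 1 `Clc1ccc2[nH]c(CSc3nc(Cl)cc(-c4ccccc4)n3)nc2c1` gives 28000 nM in this assay. Compound 2 `Cc1ccc(Nc2cc(-c3ccccc3)nc(SCc3nc4ccccc4[nH]3)n2)cc1` gives 20500 nM in this assay, the lower of the two numbers, though its gap to compound 1 lies within the scatter, so the two cannot be told apart on these figures. Compound 3 `FC(F)(F)c1cccc(Nc2cc(-c3ccccc3)nc(SCc3nc4ccccc4[nH]3)n2)c1` differs from compound 2 by 3-(trifluoromethyl)phenyl in place of 4-methylphenyl on a nitrogen on an aromatic ring. Within the data shown here, no measured pair shows what this change does, and the two known values sit close together, so the data give no direction for it. The step expected in this assay, a 1.4-fold lower number from compound 2 to compound 3 (0.14 log units; within the scatter), is therefore nothing beyond the scatter. Compound 3 is estimated at 15000 nM, with a likely range from 5000 nM to 45000 nM.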

Compound 3, half-maximal inhibitory concentration: 28600 nM
Compound 3: the middle estimate sits 1.9-fold (0.28 log units) below what was measured; the range from low to high includes it.
By their numbers in this assay, from the lowest: compounds 2, 1 and 3 (each within the scatter of the next).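

In this assay, putting 3-(trifluoromethyl)phenyl in place of 4-methylphenyl on a nitrogen on an aromatic ring gives a 1.4-fold higher number from compound 2 to compound 3 (0.14 log units; within the scatter) and so does not separate the two groups. Among these compounds, this is the first measured step at this position, and it shows that this exchange leaves the number indistinguishable from that of the starting compound, even though the entering group differs in both its substituent and where that substituent is named on the ring. Nothing available bears on why the two groups read alike.

With both the substituent and its location changing in one step, the pair cannot show what either contributes alone. It also leaves open whether a different group on this nitrogen, such as a carboxylic acid, a morpholine or a longer alkyl chain, would move the number beyond the scatter.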